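Amide aryl variation on a flavonol series: compound 4

This account rests on a few compounds, and the source may have more. Where it says the series, first, only, none or still open, it means among the compounds named here.

Measured so far in a functional assay on A549 cells (Homo sapiens) for antiproliferative activity, read by CCK-8 assay, with a stated time of 72 h; on this read-out lower numbers stand for stronger inhibition and higher numbers for weaker inhibition:
compound 1 `COc1ccc(C(=O)Nc2cccc(-c3oc4cc(-c5ccc(F)cc5)ccc4c(=O)c3O)c2)cc1` gives 8700 nM
compound 2 `Cc1ccc(C(=O)Nc2cccc(-c3oc4cc(-c5ccc(F)cc5)ccc4c(=O)c3O)c2)cc1` gives 6910 nM
compound 3 `O=C(Nc1cccc(-c2oc3cc(-c4ccc(F)cc4)ccc3c(=O)c2O)c1)c1ccc(Cl)cc1` gives 10800 nM

Compound 3 gives the highest of the three numbers, but its gaps to the others are small: a 1.2-fold higher number from compound 1 to compound 3 (0.09 log units; within the scatter) and a 1.6-fold higher number from compound 2 to compound 3 (0.19 log units; within the scatter); the remaining pair shows a 1.3-fold lower number from compound 1 to compound 2 (0.10 log units; within the scatter). None of the three steps leaves the scatter, so on present data the three compounds are not separated.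

Compound 4 `COc1ccccc1C(=O)Nc1cccc(-c2oc3cc(-c4ccc(F)cc4)ccc3c(=O)c2O)c1` differs from compound 3 by 2-methoxyphenyl in place of 4-chlorophenyl on a carbonyl carbon. Among the compounds with values here, the only measured step that exchanges chloro for methoxy is the reverse of a 1.2-fold higher number from compound 1 to compound 3 (0.09 log units; within the scatter), and it stayed within the scatter. Within the data shown here, the methoxy group of compound 4 sits on the 2-methoxyphenyl group rather than where compound 1 carries it, so no measured step covers this change exactly. Three substituent exchanges on the amide aryl group have all been flat in this assay, so the expectation for compound 4 is no step beyond the scatter in either direction: an estimated 1.2-fold lower number from compound 3 to compound 4 (0.08 log units; within the scatter). Compound 4 is expected to give about 9000 nM, in the range 4000 nM to 20000 nM.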

Compound 4, half-maximal inhibitory concentration: 11700 nM
Estimate against measurement, compound 4: 1.3-fold (0.11 log units) below; the range from low to high includes it.
By their numbers in this assay, from the lowest: compounds 2, 1, 3 and 4 (each within the scatter of the next).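

In this assay, within the data shown here, compound 4 gives the first reading on where the methoxy group sits on the amide aryl group: 2-methoxyphenyl in place of 4-methoxyphenyl gives no separation (a 1.3-fold higher number from compound 1 to compound 4 (0.13 log units; within the scatter)). Its exchanges for 4-chlorophenyl (a 1.1-fold higher number from compound 3 to compound 4 (0.03 log units; within the scatter)) and for 4-methylphenyl (a 1.7-fold higher number from compound 2 to compound 4 (0.23 log units; within the scatter)) also stay within the scatter, so the change of substituent place adds no separation to the flat picture from the substituent exchanges, and the four compounds remain unseparated. Nothing at hand accounts for this flatness.

Open, on these data alone, is whether an amine or a carboxylic acid on this aryl group, or a longer chain in its place, would give a step beyond the scatter. The compounds shown also leave open how changes away from the amide aryl group, such as to the 4-fluorophenyl group, would read here.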